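Swapping a Difluorophenyl Ketone for a Furan Ketone

This account rests on a few compounds, and the source may have more. Where it says the series, first, only, none or still open, it means among the compounds named here.

Compound 1, `COc1cc(-c2nnc3n2NC(c2cccs2)C(C(=O)c2ccccc2)S3)cc(OC)c1OC`: 86300 nM
Compound 2, `COc1cc(-c2nnc3n2NC(c2cccs2)C(C(=O)c2ccc(C)cc2)S3)cc(OC)c1OC`: 5090 nM
Compound 3, `COc1cc(-c2nnc3n2NC(c2ccco2)C(C(=O)c2ccc(F)c(F)c2)S3)cc(OC)c1OC`: 36000 nM

These three compounds share one core and were tested in a functional assay on PC-3 cells (Homo sapiens) for cytotoxicity, read by MTT assay, with a stated time of 48 h (on this read-out higher numbers stand for weaker inhibition and lower numbers for stronger inhibition), which reports the concentration at which the growth signal of prostate cancer cells is reduced to half-maximal. Compound 3 stands second highest of the three numbers: its nearest neighbour is compound 1, with a higher number, and its furthest is compound 2, with a clearly lower number.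

Compound 4, `COc1cc(-c2nnc3n2NC(c2ccco2)C(C(=O)c2ccco2)S3)cc(OC)c1OC`, has not yet been measured. It differs from compound 3 in one place: furan-2-yl in place of 3,4-difluorophenyl on a carbonyl carbon.

Going by the values given here, only one single-point step is available for comparison, a 17-fold lower number from compound 1 to compound 2 (1.23 log units; beyond the scatter). That step shows that a small change on an aromatic carbon of the ketone-bearing ring can shift this assay strongly, but it involves a different change and gives no direction for replacing the whole ring. Compound 1 and compound 3 differ in two places, so their values alone only show that both lie in the weak range.

Among the compounds with values here, with no directly relevant step, compound 4 is expected to land near compound 3, and the step of a 1.1-fold higher number from compound 3 to compound 4 (0.05 log units; within the scatter) is estimated to stay within the scatter. The estimate for compound 4 is therefore 40000 nM, with a wide range from 8000 nM to 200000 nM.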

Compound 4, half-maximal inhibitory concentration: 58300 nM
Beside the measured number, compound 4's estimate is 1.5-fold (0.16 log units) below it; the range from low to high includes it.
By their numbers in this assay, from the lowest: compound 2; then compounds 3, 4 and 1 (each within the scatter of the next, the first and the last beyond it).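

In this assay, the move from a six-membered carbon ring carrying two fluorines to a five-membered ring with one oxygen gives a 1.6-fold higher number from compound 3 to compound 4 (0.21 log units; within the scatter), so replacing the entire 3,4-difluorophenyl group with furan-2-yl on this carbonyl carbon leaves the reading within the usual scatter. The earlier step, a 17-fold lower number from compound 1 to compound 2 (1.23 log units; beyond the scatter), showed that a single methyl on an aromatic carbon of a ring on the ketone can matter a great deal; this new step shows that a much larger swap of the ring on the ketone need not move the number at all. Nothing available here explains why these two different rings read alike.

The compounds shown leave open whether an aromatic ring is needed on this carbonyl carbon at all, since a morpholine or a plain propyl chain in that place could tell a different story. They also leave open whether a methyl group on the furan-2-yl ring of compound 4 would produce a large step like the one seen with the methyl group of compound 2.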